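The source may hold more compounds than are shown below. What is called first, only, known or untested is meant among the compounds shown, and "the series" means these compounds.

For the measured compounds named here, compound 1 `CCOc1c(-c2cc(OC)c(OC)c(OC)c2)oc2ccccc2c1=O` is the only member of the series with a number in a functional assay on DU-145 cells (Homo sapiens) for antiproliferative activity, read by WST assay, with a stated time of 3 days (on this read-out higher numbers stand for weaker inhibition and lower numbers for stronger inhibition), where compound 1 gives 6200 nM. Compound 2 `CCCCCCCOc1c(-c2cc(OC)c(OC)c(OC)c2)oc2ccccc2c1=O` reaches only a limit of the assay in this assay, at > 50000 nM. Going by the values given here, that step, an at least 8.0-fold higher number from compound 1 to compound 2 (0.90 log units; beyond the scatter), is the one comparison that bears on compound 3 `CCCCN(CCCC)CCCOc1c(-c2cc(OC)c(OC)c(OC)c2)oc2ccccc2c1=O`, which differs from compound 1 by (dibutylamino)methyl in place of hydrogen on a saturated chain carbon, two bonds along the chain from an oxygen on an aromatic ring, the same place in the chain that was extended in compound 2. A weakening of similar size, toward a higher number, is therefore expected, with the step of a 4.0-fold higher number from compound 1 to compound 3 (0.61 log units; beyond the scatter). Compound 3 is estimated at 25000 nM, within 6000 nM to 80000 nM.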

Compound 3, half-maximal inhibitory concentration: 15700 nM
Beside the measured number, compound 3's estimate is 1.6-fold (0.20 log units) above it, within the range that was stated.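

In this assay, a long chain on this oxygen is not lost outright once it carries an amine, though the change still costs activity, with a 2.5-fold higher number from compound 1 to compound 3 (0.40 log units; beyond the scatter). At the far end of the chain, dibutylamino in place of butyl gives an at least 3.1-fold lower number from compound 2 to compound 3 (0.50 log units; beyond the scatter), so the identity of the chain end matters and not only its length. That step is only a bound, as compound 2 stands at a limit and not at a number: the limit of > 50000 nM in this assay, at which 1 of the 3 values shown sits.

On these data alone, it remains open whether the nitrogen itself or the two butyl groups on it set this difference. A primary amine or piperidine at the chain end, or a shorter 2-(dibutylamino)ethyl chain, would help separate these.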